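A few compounds are considered here, and "the series" means these few. Any claim that something is new, unique, unknown or untested is made for them only; others in the source may bear on it.

In a functional assay on HepG2 cells (Homo sapiens) for inhibition, read by MTT assay, with a stated time of 24 h (a higher number here means a weaker inhibitor, a lower number a stronger inhibitor), compound 1 `C[C@]1(C(=O)NCCOc2ccc(C3CCCCC3)cc2)CO[C@@H](c2ccccc2)OC1` gives 32900 nM. Compound 3 `O=C(CNC(=O)c1cccnc1Cl)N/N=C/c1ccccc1OCc1ccccc1Cl` gives 16900 nM in this assay. These two numbers lie within the usual scatter of each other, so neither compound can be ranked ahead of the other. Compound 2 `CCN(CC)c1ccc(/C=N/NC(=O)CNC(=O)c2ccc(F)cc2)c(OCc2ccccc2Cl)c1` is recorded only as a limit of the assay, > 50000 nM, and not as a number.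

Compound 4 `N#Cc1ccc(C(=O)NCC(=O)N/N=C/c2ccccc2OCc2ccccc2Cl)cc1` keeps the rest of compound 3 and changes one group: 4-cyanophenyl stands in place of 2-chloropyridin-3-yl on a carbonyl carbon (4-cyanophenyl in place of 2-chloropyridin-3-yl on a carbonyl carbon). The swap exchanges a six-membered aromatic ring with one hetero atom for one of carbon only, and the new group brings a triple bond outside the aromatic ring. Within the data shown here, no pair of measured compounds differs in a single place, so the data offer no direct guide to the size of this change. The expectation therefore rests on compound 3 at 16900 nM, and no shift beyond the scatter is anticipated in this assay. The expected step of a 1.2-fold higher number from compound 3 to compound 4 (0.07 log units; within the scatter) is an estimate that stays within that scatter. For compound 4 the estimated value is 20000 nM, with an expected range from 8000 nM to 50000 nM.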

Compound 4, half-maximal inhibitory concentration: > 50000 nM
Compound 4: only a limit was reported; the forecaster's own chance of this, stated with the estimate: 20%; middle value at least 2.5-fold (0.39 log units) from the limit.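

The exchange of 2-chloropyridin-3-yl for 4-cyanophenyl on a carbonyl carbon gives, in this assay, an at least 2.9-fold higher number from compound 3 to compound 4 (0.47 log units; beyond the scatter), the first step among the compounds shown that can be read for a change in one place. It shows that this place is not indifferent to the group it carries: with the rest of compound 3 kept, the new group leaves the inhibition weaker by more than the usual scatter. Compound 4 carries a limit and not a number, so the step gives only a lower bound on the size of the change, and the same limit recurs in the set: the limit of > 50000 nM in this assay, at which 2 of the 4 values shown sit.

This single step changes the ring, the chlorine and the nitrile together, and the compounds shown do not separate them. From the compounds shown here alone, it remains open whether a 2-chlorophenyl group, or a pyridin-3-yl group without the chlorine, on the same carbonyl carbon would keep compound 3 at 16900 nM, or whether a group bearing an amine or a carboxylic acid would bring a stronger reading.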